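Aryl substituent swap on the core of compound 3

The source may report more compounds than this note shows. Statements on the series, on what has been measured and on what is new or still open speak of the compounds shown alone.

Compound 1 `Cc1ccc(CC(C)C(=O)N2CCN(c3ccc(C(F)(F)F)cc3[C@@H](N)CC(C)C)CC2)cc1C`, compound 2 `CC(C)C[C@H](N)c1cc(C(F)(F)F)ccc1N1CCN(C(=O)COc2ccc(O)cc2)CC1` and compound 3 `CC(C)C[C@H](N)c1cc(C(F)(F)F)ccc1N1CCN(C(=O)C(C)Cc2ccc(Cl)cc2)CC1` share one core and differ only in the acyl group carried on the amide nitrogen. In an assay on HEK293 cells for displacement of a labelled ligand from Melanocortin receptor 4 (Homo sapiens) (on this read-out lower numbers stand for stronger inhibition and higher numbers for weaker inhibition), compound 1 gives 240 nM, compound 2 gives 4600 nM and compound 3 gives 47 nM. Compound 3 stands lowest of the three: a 5.1-fold lower number from compound 1 to compound 3 (0.71 log units; beyond the scatter) and a 98-fold lower number from compound 2 to compound 3 (1.99 log units; beyond the scatter), while a 19-fold higher number from compound 1 to compound 2 (1.28 log units; beyond the scatter) places compound 2 as the weakest member of the set. Compound 4 `CC(C)C[C@H](N)c1cc(Cl)ccc1N1CCN(C(=O)C(C)Cc2ccc(Cl)cc2)CC1` is the next step from compound 3: chloro in place of trifluoromethyl on an aromatic carbon. For the measured compounds named here, every measured step so far alters the acyl side of the molecule; none touches the aromatic ring of the core that carries the trifluoromethyl group, so no measured step bears directly on this change. The acyl part that gives compound 3 its low number is kept unchanged in compound 4. Going by the values given here, with no precedent on this position, the expectation for compound 4 in this assay is a step that is small or within the scatter, with some allowance for a weaker number: a 1.7-fold higher number from compound 3 to compound 4 (0.23 log units; within the scatter) is the estimated step. Compound 4 is thus estimated at 80 nM, with a range from 25 nM to 250 nM.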

Compound 4, inhibition constant: 67 nM
Compound 4: the middle estimate sits 1.2-fold (0.08 log units) above what was measured, and the stated range covers the measured number.
By their numbers in this assay, from the lowest: compounds 3 and 4 (each within the scatter of the next); then compound 1; then compound 2.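

In this assay, for the compounds shown here, the first measured change on the aromatic ring of the shared core, chloro in place of trifluoromethyl, gives a 1.4-fold higher number from compound 3 to compound 4 (0.15 log units; within the scatter); with the acyl group of compound 3 held constant, the exchange of 4 heavy atoms for 1 at this position, para to a large group, leaves the two compounds indistinguishable on this read-out. This step is small beside those seen on the acyl side of the series, such as a 5.1-fold lower number from compound 1 to compound 3 (0.71 log units; beyond the scatter) and a 98-fold lower number from compound 2 to compound 3 (1.99 log units; beyond the scatter), so among the changes shown, the acyl group marks the large differences and this ring position does not. No available evidence accounts for the interchange of these two groups at this position.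

The compounds shown cover only trifluoromethyl and chloro here, leaving open how a nitrile, a methoxy group, a carboxylic acid or a bare hydrogen at the same position would read. The exchange also rests on a single matched pair, so whether it holds with the acyl groups of compound 1 or compound 2 remains an open question.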